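This account rests on a few compounds, and the source may have more. Where it says the series, first, only, none or still open, it means among the compounds named here.

Compound 2, `CCCCC(=O)OC[C@H]1O[C@@H](n2cnc3c(OC)ncnc32)[C@@H](OC(=O)CCCC)[C@@H]1OC(=O)CCCC`, was measured in a physicochemical assay for solubility, in phosphate buffer (a lower number here means a less soluble compound, a higher number a more soluble compound), and gave 21000 nM. Among the three compounds measured in this assay it holds the second highest number. Its nearest neighbour is compound 3, `COc1ncnc2c1ncn2[C@@H]1O[C@H](COC(=O)C(C)(C)C)[C@@H](OC(=O)C(C)(C)C)[C@@H]1OC(=O)C(C)(C)C`, which in this assay gives 14000 nM, a number within the scatter of that of compound 2. The furthest is compound 1, `CCCC(=O)OC[C@H]1O[C@@H](n2cnc3c(OC)ncnc32)[C@@H](OC(=O)CCC)[C@@H]1OC(=O)CCC`, which in this assay gives 102000 nM, a number beyond the scatter from that of compound 2.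

Compound 4, `CCCCC(=O)O[C@H]1[C@H](OC(=O)CCCC)[C@@H](CO)O[C@H]1n1cnc2c(OC)ncnc21`, has not yet been measured in this assay. It differs from compound 2 in one place: hydrogen in place of butylcarbonyl on an oxygen on a saturated carbon. Within the data shown here, no step between two measured compounds isolates a change of this kind, so no measured step can be borrowed directly. What the numbers do show is that compound 1 and compound 2 differ only in their ester chains, and compound 1 gives the higher number. Losing one ester chain altogether is expected to move the number in the same direction, and by more than the scatter. Compound 4 is therefore estimated in this assay at 150000 nM, within a range from 50000 nM to 500000 nM. This estimate corresponds to an expected 7.1-fold higher number from compound 2 to compound 4 (0.85 log units; beyond the scatter), a rise in solubility.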

Compound 4, solubility: 694000 nM
The estimate for compound 4 lay 4.6-fold (0.67 log units) below the measured number; the whole stated range lies below it.
By their numbers in this assay, from the lowest: compounds 3 and 2 (each within the scatter of the next); then compound 1; then compound 4.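

Among these compounds, the step is the first to isolate a single place: with hydrogen in place of butylcarbonyl on the oxygen of the hydroxymethyl group, this assay reads a 33-fold higher number from compound 2 to compound 4 (1.52 log units; beyond the scatter). The earlier compounds shown here differ from one another at all their ester positions at once, so they could not show what any one of these positions contributes; this step shows that a change at this one oxygen is enough for a large move in the number, while the other butylcarbonyl esters stay in place. No measurement shown here accounts for the size of the step, so the result stands as an observation without an explanation.

The compounds shown leave open whether the same change on either of the other ester oxygens would give a step of similar size, and whether removing further butylcarbonyl groups would add to it. They also leave open how this oxygen would behave if it carried an acetyl ester, an ester with an amine on its chain, or a phosphate in place of the hydrogen.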